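The source may report more compounds than this note shows. Statements on the series, on what has been measured and on what is new or still open speak of the compounds shown alone.

Measured so far:
- compound 1, `CC1(C)CC(C)(C)c2cc(NC(=O)Nc3ccc([N+](=O)[O-])cc3)ccc2O1`: 4100 nM in a functional assay on A2780 cells (Homo sapiens) for inhibition, with a stated time of 72 h; a lower number here means a stronger inhibitor, a higher number a weaker inhibitor
- compound 2, `CC1(C)CC(C)(C)c2cc(N/C(S)=N/c3ccc([N+](=O)[O-])cc3)ccc2O1`: 6960 nM in this assay

Compound 1 has the lowest number of the two; its nearest neighbour, compound 2, lies within the scatter, so the two cannot be ranked against each other. Compound 3, `CC1(C)CC(C)(C)c2cc(NC(=O)Nc3ccc(OC(F)(F)F)cc3)ccc2O1`, has not yet been measured. It differs from compound 1 by a single change: trifluoromethoxy in place of nitro on an aromatic carbon. Both compounds keep the same urea link and the same shared core; only the group on the far aromatic ring is exchanged. Among the compounds with values here, no measured pair shows this kind of exchange, so the size and direction of the step cannot be read from the data. The expectation is a step of modest size, within or just beyond the scatter, with no firm direction, so compound 3 is estimated at 5000 nM, within 1500 nM to 16000 nM, which is expected to correspond to a step of a 1.2-fold higher number from compound 1 to compound 3 (0.09 log units; within the scatter).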

Compound 3, half-maximal inhibitory concentration: 4560 nM
The estimate for compound 3 lay 1.1-fold (0.04 log units) above the measured number, and the stated range covers the measured number.
By their numbers in this assay, from the lowest: compounds 1, 3 and 2 (each within the scatter of the next).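

Trifluoromethoxy in place of nitro, on an aromatic carbon para to a large group, gives a 1.1-fold higher number from compound 1 to compound 3 (0.05 log units; within the scatter) in this assay. This is the first exchange shown at this position, and with the urea link and the shared core kept, it leaves compound 1 and compound 3 impossible to rank. Two groups with different atoms can therefore stand here without a difference that this assay can resolve. No measurement offered here gives a reason for this result.

The compounds shown leave open whether an amine, a carboxylic acid or a simple hydrogen at this position would move the number beyond the scatter. They also leave open whether trifluoromethoxy would give a similar result on the sulfur-containing link of compound 2.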